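The source may hold more compounds than are shown below. What is called first, only, known or untested is meant among the compounds shown, and "the series" means these compounds.

Measured compounds:
compound 1 `CC1=C(C(=O)OCCc2ccccc2)C(c2csc(-c3ccc(Cl)cc3)n2)C(C(=O)OCCc2ccccc2)=C(C)N1`, in an assay on isolated protein for antagonist activity at Voltage-dependent L-type calcium channel subunit alpha-1C (Cavia porcellus), with a stated time of 15 min (a higher number here means a weaker inhibitor, a lower number a stronger inhibitor), compound 1 gives 500000 nM.
compound 2 `CCOC(=O)C1=C(C)NC(C)=C(C(=O)OC)C1c1csc(-c2ccc(Cl)cc2)n1`, in this assay compound 2 gives 22000 nM.
compound 3 `COC(=O)C1=C(C)NC(C)=C(C(=O)OC2CCCCC2)C1c1csc(-c2ccc(Cl)cc2)n1`, in this assay compound 3 gives 71900 nM.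

Compound 3 sits second highest of the three numbers: its nearest neighbour is compound 2, and the move a 3.3-fold higher number from compound 2 to compound 3 (0.51 log units; beyond the scatter) is beyond the scatter; the furthest is compound 1, whose number lies well above that of compound 3.

The step to compound 4 `COC(=O)C1=C(C)NC(C)=C(C(=O)OCCc2ccccc2)C1c1csc(-c2ccc(Cl)cc2)n1` is phenethyl in place of cyclohexyl on an oxygen next to a carbonyl group. For the measured compounds named here, only one measured step touches this ester oxygen, a 3.3-fold higher number from compound 2 to compound 3 (0.51 log units; beyond the scatter), which shows that enlarging the group there raised the number modestly. Going by the values given here, compound 1 carries phenethyl on both ester oxygens and gives the highest number of the set, but no single step to it is available, so its value only hints that phenethyl is not favourable here. Among the compounds with values here, for compound 4 a further increase beyond the scatter is expected, a 2.5-fold higher number from compound 3 to compound 4 (0.40 log units; beyond the scatter), though smaller than the gap to compound 1 since only one ester changes. Compound 4 is estimated at 180000 nM, within 60000 nM to 500000 nM.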

Compound 4, half-maximal inhibitory concentration: 10200 nM
Compound 4: middle estimate off by 18-fold (1.25 log units), on the high side; measured number below the stated range.
By their numbers in this assay, from the lowest: compound 4; then compound 2; then compound 3; then compound 1.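

Notes on the ester oxygen, read in this assay: the earlier rise with cyclohexyl does not mean that any larger group there raises the number, since phenethyl in place of cyclohexyl gives a 7.0-fold lower number from compound 3 to compound 4 (0.85 log units; beyond the scatter), and the comparison with the ethyl ester of compound 2 gives a 2.2-fold lower number from compound 2 to compound 4 (0.33 log units; beyond the scatter). The ring type and its distance from the ester oxygen therefore matter at this position, with compound 3 and compound 4 going opposite ways from compound 2. Phenethyl is tolerated on one ester only in this set, as hydrogen in place of benzyl on the chain of the second ester gives a 49-fold lower number from compound 1 to compound 4 (1.69 log units; beyond the scatter).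

Open, going by these compounds, is whether a benzyl ester, a longer chain ending in phenyl, or a pyridylethyl ester would follow compound 4. Nothing available accounts for these shifts.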